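The compounds below may be only part of what the source reports. "The series", "measured", "known", "first", "only" and "open" are said of these compounds alone.

Values in a functional assay on HCT-116 cells (Homo sapiens) for cytotoxicity, read by MTT assay, with a stated time of 72 h; on this read-out higher numbers stand for weaker inhibition and lower numbers for stronger inhibition:

- compound 1 `COc1ccc(NC(=O)Nc2ccc(C(=O)NO)cc2)cc1`: 22300 nM
- compound 2 `COc1ccc(NC(=O)Nc2ccc(/C=C/C(=O)NO)cc2)cc1`: 11900 nM
- compound 3 `O=C(CCc1ccc(NC(=O)Nc2ccc(Cl)cc2)cc1)NO`: 17900 nM

The values of compound 3 and of the other two compounds all lie within the scatter of one another, so compound 3 is not set apart from them. Compound 4 `COc1ccc(NC(=O)Nc2ccc(CCC(=O)NO)cc2)cc1` is reached from compound 3 by methoxy in place of chloro on an aromatic carbon. Within the data shown here, no measured step makes this exchange directly. Among the measured compounds shown here, the only step available, a 1.9-fold lower number from compound 1 to compound 2 (0.27 log units; within the scatter), concerns a different group and stays within the scatter. Still, the two compounds bearing 4-methoxyphenyl, compound 1 at 22300 nM and compound 2 at 11900 nM, do not stand apart from chloro-bearing compound 3 at 17900 nM. No step beyond the scatter is therefore expected in this assay, and the estimated 1.1-fold lower number from compound 3 to compound 4 (0.02 log units; within the scatter) is correspondingly small. For compound 4 the estimated value is 17000 nM, with an expected range from 8000 nM to 35000 nM.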

Compound 4, half-maximal inhibitory concentration: 31000 nM
Beside the measured number, compound 4's estimate is 1.8-fold (0.26 log units) below it; low and high end bracket the measured number.
By their numbers in this assay, from the lowest: compounds 2, 3, 1 and 4 (each within the scatter of the next, the first and the last beyond it).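

In this assay, methoxy in place of chloro, para to a large group, gives a result within the scatter (a 1.7-fold higher number from compound 3 to compound 4 (0.24 log units; within the scatter)), so 4-chlorophenyl and 4-methoxyphenyl are not told apart on this chain. With 4-methoxyphenyl held constant, the 2-(hydroxycarbamoyl)ethyl compound shows a modest step beyond the scatter against the ethenyl one (a 2.6-fold higher number from compound 2 to compound 4 (0.42 log units; beyond the scatter)), but not against the hydroxycarbamoyl one (a 1.4-fold higher number from compound 1 to compound 4 (0.14 log units; within the scatter)). Nothing measured here accounts for these steps. Still open, going by these compounds, is whether an amine or a carboxylic acid at this position would separate from chloro and methoxy. On these data alone, whether a longer chain carrying the hydroxycarbamoyl group would change the number is also open.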